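Cytotoxicity notes: amide-chain variation on the shared core

This account rests on a few compounds, and the source may have more. Where it says the series, first, only, none or still open, it means among the compounds named here.

Measured compounds:
compound 1 `CC(=O)Nc1ccc(-c2nc3ccccc3[nH]2)cc1` — > 100000 nM
compound 2 `CC(=O)Nc1ccc(-c2nc3cc(C(F)(F)F)ccc3[nH]2)cc1` — 53000 nM

In an ADME assay on BHK cells (Mesocricetus auratus) for cytotoxicity, read by MTT assay, with a stated time of 96 h (on this read-out higher numbers stand for lower toxicity in this test and lower numbers for higher toxicity in this test), compound 1 reaches only a limit, > 100000 nM, so its place on the numbers is known solely as that limit (the limit of > 100000 nM in this assay, at which 1 of the 2 values shown sits). Going by the values given here, the one measured step, an at least 1.8-fold lower number from compound 1 to compound 2 (0.27 log units; that floor lies within the scatter), concerns trifluoromethyl in place of hydrogen on an aromatic carbon and stays within the scatter at its floor.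

Compound 3 `O=C(CN1CCCC1)Nc1ccc(-c2nc3ccccc3[nH]2)cc1` differs from compound 1 by pyrrolidin-1-yl in place of hydrogen on a saturated chain carbon bound to a carbonyl carbon. Among the compounds with values here, no measured step touches this part of the structure. With nothing pointing either way, the expected step is a number no higher from compound 1 to compound 3 (the limit leaves the size open), none beyond the scatter. Compound 3 is estimated at 100000 nM, between 30000 nM and 300000 nM.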

Compound 3, half-maximal cytotoxic concentration: 55000 nM
Estimate against measurement, compound 3: 1.8-fold (0.26 log units) above; the range from low to high includes it.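

Pyrrolidin-1-yl on the saturated chain carbon bound to a carbonyl carbon gives the first reading for a change at this position in this assay, with an at least 1.8-fold lower number from compound 1 to compound 3 (0.25 log units; that floor lies within the scatter). The true size of this step stays open, and a floor within the scatter does not show that the change is without effect, because the value for compound 1 is a limit: the limit of > 100000 nM in this assay, at which 1 of the 3 values shown sits.

Still open, going by these compounds, is how the number responds to an open-chain amine or a carboxylic acid on this carbon, or to a longer chain between the carbonyl and pyrrolidin-1-yl.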